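Swapping the aminophenyl for a dimethoxyphenyl on the carbonyl

This account rests on a few compounds, and the source may have more. Where it says the series, first, only, none or still open, it means among the compounds named here.

Compound 1 `COc1ccc(-c2cc(/C=C/C(=O)c3ccc(N)cc3)[nH]n2)cc1`: 58%
Compound 2 `COc1cc(-c2cc(/C=C/C(=O)c3ccc(N)cc3)[nH]n2)cc(OC)c1OC`: 43%

In a functional assay on K562 cells (Homo sapiens) for cytotoxicity, read by sulforhodamine B assay, with a stated time of 48 h, tested at 1 uM (on this read-out lower numbers stand for a stronger effect and higher numbers for a weaker effect at the one concentration tested), compound 2 gives 43%, the lowest of the two numbers, while compound 1 sits higher, beyond the scatter. Compound 3 `COc1ccc(C(=O)/C=C/c2cc(-c3cc(OC)c(OC)c(OC)c3)n[nH]2)cc1OC` differs from compound 2 in one place: 3,4-dimethoxyphenyl in place of 4-aminophenyl on a carbonyl carbon. For the measured compounds named here, no measured pair shows what such a change on a carbonyl carbon does here, so the expectation rests on compound 2 alone. The step from compound 2 to compound 3 in this assay is expected to be small, a number 7 percentage points higher from compound 2 to compound 3 (within the scatter), in either direction or none beyond the scatter. Compound 3 is therefore estimated at 50%, within 25% to 80%.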

Compound 3, a percentage reported as activity, at one concentration (the size of the read-out at that concentration, not a potency): 75%
Compound 3: the middle estimate sits 25 percentage points below what was measured; low and high end bracket the measured number.
By their numbers in this assay, from the lowest: compound 2; then compound 1; then compound 3.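

In this assay the swap of 4-aminophenyl for 3,4-dimethoxyphenyl gives a number 32 percentage points higher from compound 2 to compound 3 (beyond the scatter) and so a weaker effect, which shows that the group on this carbonyl carbon strongly affects the result. The earlier compounds shown here, which both carry 4-aminophenyl here, could not show this. Nothing measured on these compounds explains the loss.

Going by these compounds, it remains open whether the departing amine or the entering methoxy groups drive the step. A plain phenyl or a 4-hydroxyphenyl on this carbonyl carbon could help separate the two.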